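Methylpiperazinyl in Place of Amino at the Carbonyl Carbon

This account rests on a few compounds, and the source may have more. Where it says the series, first, only, none or still open, it means among the compounds named here.

Compound 1 `NC(=O)/C=C/c1ccncc1-c1ccc2ccccc2c1` was tested in a functional assay on MCF7 cells (Homo sapiens) for inhibition, read by sulforhodamine B assay, with a stated time of 72 h; a lower number here means a stronger inhibitor of growth, a higher number a weaker inhibitor of growth. In this assay compound 1 reaches only a limit of measurement, > 10000 nM, not a number. Its companion compound 2 `CNC(=O)/C=C/c1ccncc1-c1ccc2c(ccn2C)c1` gives 7120 nM in this assay. What is known of compound 1 is therefore (the limit of > 10000 nM in this assay, at which 1 of the 2 values shown sits). Compound 3 `CN1CCN(C(=O)/C=C/c2ccncc2-c2ccc3ccccc3c2)CC1` differs from compound 1 by 4-methylpiperazin-1-yl in place of amino on a carbonyl carbon. Going by the values given here, no measured step covers this change, so no movement beyond the scatter is expected in this assay. Compound 3 is estimated at 10000 nM, with a range from 3000 nM to 30000 nM. The expected step is a number no higher from compound 1 to compound 3 (the limit leaves the size open).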

Compound 3, concentration for 50% growth inhibition: > 10000 nM
Compound 3 was reported as a limit; the forecaster's own chance of this, stated with the estimate: 50%; the middle value sits exactly at the limit.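

Compound 1 and compound 3 both stand at a limit of measurement in this assay, so no step between them can be read: the limit of > 10000 nM in this assay, at which 2 of the 3 values shown sit.

Going by these compounds, whether 4-methylpiperazin-1-yl in place of amino on a carbonyl carbon changes growth inhibition at all stays open.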